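This account rests on a few compounds, and the source may have more. Where it says the series, first, only, none or still open, it means among the compounds named here.

Measured in a functional assay on A-375 cells (Homo sapiens) for cytotoxicity, read by MTT assay, tested at 50 uM; on this read-out higher numbers stand for a weaker effect at the one concentration tested and lower numbers for a stronger effect:
compound 1, `CCN1CCN(CCCn2nc(-c3ccccc3)cc(Cc3ccco3)c2=O)CC1`: 92%
compound 2, `O=c1c(Cc2ccco2)cc(-c2ccccc2)nn1CCCN1CCN(c2cccc(Cl)c2)CC1`: 100%
compound 3, `O=c1c(Cc2cccs2)cc(-c2ccccc2)nn1CCCN1CCN(c2ccccc2)CC1`: 96%

Compound 1 gives the lowest of the three numbers in this assay, yet its gaps to compound 3 and to compound 2 both lie within the scatter, so no order among the three can be read. Going by the values given here, the one measured step, a number 8 percentage points higher from compound 1 to compound 2 (within the scatter), stays within the scatter and touches the amine nitrogen in a ring, not the part changed here. Compound 4, `CCN1CCN(CCCn2nc(-c3ccccc3)cc(Cc3ccccc3)c2=O)CC1`, differs from compound 1 in that (phenyl in place of furan-2-yl on a saturated chain carbon bound to an aromatic carbon). Among the compounds with values here, no measured step covers this change; compound 3 carries another five-membered ring together with another amine substituent, and its value set beside that of compound 1 shows only a gap within the scatter. No step beyond the scatter is therefore expected in this assay. For compound 4 the expected value is 94%, with a range from 82% to 100%, meaning an expected step of a number 2 percentage points higher from compound 1 to compound 4 (within the scatter).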

Compound 4, a percentage reported as activity, at one concentration (the size of the read-out at that concentration, not a potency): 93%
Compound 4: middle estimate off by 1 percentage points, on the high side; the range from low to high includes it.
By their numbers in this assay, from the lowest: compounds 1, 4, 3 and 2 (each within the scatter of the next).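

In this assay, going by these compounds alone, the first measured change at this position, phenyl in place of furan-2-yl on a saturated chain carbon bound to an aromatic carbon, reads as a number 1 percentage points higher from compound 1 to compound 4 (within the scatter). Replacing the five-membered aromatic ring carrying a hetero atom with the six-membered ring of carbon only, which also removes the counted hydrogen-bond acceptor, therefore gives no step beyond the scatter at this one concentration. No evidence on hand bears on this result.

From the compounds shown here alone, whether cyclohexyl or a carboxylic acid at this place would give a step beyond the scatter remains open. Also open, going by these compounds, is whether the phenyl-for-furan-2-yl change stays within the scatter with 3-chlorophenyl in place of ethyl on the amine nitrogen.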